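This account rests on a few compounds, and the source may have more. Where it says the series, first, only, none or still open, it means among the compounds named here.

Compound 2 `CNc1nc2c(ncn2-c2ccccc2)c(=O)n1-c1ccc(Cl)cc1` stands at the edge of what the assay can report: in a functional assay on HepG2 cells (Homo sapiens) for cytotoxicity, read by MTT assay, with a stated time of 72 h (on this read-out lower numbers stand for stronger inhibition and higher numbers for weaker inhibition), compound 2 gives > 100000 nM, a limit and not a number. Compound 1 `CCCCCN(CCCCC)c1nc2c(ncn2-c2ccccc2)c(=O)n1-c1ccc(Cl)cc1` likewise sits at a limit, giving > 100000 nM in this assay. The step from compound 1 to compound 2 is accordingly a step that the two limits leave unreadable from compound 1 to compound 2. Compound 3 `CCCCNc1nc2c(ncn2-c2ccccc2)c(=O)n1-c1ccc(Cl)cc1` differs from compound 2 by propyl in place of hydrogen on a saturated chain carbon bound to a nitrogen on an aromatic ring. For the measured compounds named here, only that one measured step bears on it, and since both values sit at the limit of > 100000 nM in this assay, at which 2 of the 2 values shown sit, no step beyond the scatter in either direction is expected. The expected change is a step that the limit leaves unreadable from compound 2 to compound 3. Compound 3 is estimated at 120000 nM, within 30000 nM to 400000 nM.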

Compound 3, half-maximal inhibitory concentration: 77600 nM
Estimate against measurement, compound 3: 1.5-fold (0.19 log units) above; the range from low to high includes it.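

Among the compounds shown, only compound 3 gives a number rather than a limit in this assay, so butylamino is the one group on this aromatic carbon with a readable value: the limit of > 100000 nM in this assay, at which 2 of the 3 values shown sit.
The change gives an at least 1.2-fold lower number from compound 2 to compound 3 (0.11 log units; that floor lies within the scatter), and the replacement of dipentylamino gives an at least 1.2-fold lower number from compound 1 to compound 3 (0.11 log units; that floor lies within the scatter). Neither floor establishes a difference beyond the scatter, though the true gaps may be larger.

The compounds shown leave open how far a propylamino or hexylamino group at this place would shift the number. They also leave open what a carboxylic acid at the end of the butyl chain would do.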